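The source may hold more compounds than are shown below. What is called first, only, known or untested is meant among the compounds shown, and "the series" means these compounds.

Compound 1 `C=C(c1ccc(OC)cc1NC(=O)CO)c1ccc(OC)c2c1OC(C)(C)C=C2`: 40 nM
Compound 2 `COc1ccc(C(=O)c2cc(OC)c(OC)c(OC)c2)c(NC(=O)CN(C)C)c1`: 590 nM

In a functional assay on A549 cells (Homo sapiens) for antiproliferative activity, read by MTT assay, with a stated time of 48 h (on this read-out lower numbers stand for stronger inhibition and higher numbers for weaker inhibition), compound 1 gives 40 nM, the lower of the two numbers, and the gap up to compound 2 lies beyond the scatter. Compound 3 `C=C(c1ccc(OC)cc1NC(=O)CN)c1ccc(OC)c2c1OC(C)(C)C=C2` keeps the core of compound 1 and changes one group: amino in place of hydroxy on a saturated chain carbon bound to a carbonyl carbon. Among the compounds with values here, no measured pair shows this swap, so only a small change is expected. The expected step is a 1.3-fold higher number from compound 1 to compound 3 (0.10 log units; within the scatter), which stays within the scatter. For compound 3 the estimated value is 50 nM, with an expected range from 15 nM to 200 nM.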

Compound 3, half-maximal inhibitory concentration: 50 nM
The estimate for compound 3 equals the measured number at the digits printed; the range from low to high includes it.
By their numbers in this assay, from the lowest: compounds 1 and 3 (each within the scatter of the next); then compound 2.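

In this assay, within the data shown here, amino in place of hydroxy on a saturated chain carbon bound to a carbonyl carbon gives a 1.3-fold higher number from compound 1 to compound 3 (0.10 log units; within the scatter), the first comparison here of compounds that differ in one place. At this position, then, the hydroxy is not needed to keep the number within the scatter of compound 1, and amino serves equally well. Nothing measured here says why the two groups read alike. Still open, on these data alone, is how this position would respond to a larger change, such as a carboxylic acid or a longer chain carrying the amine.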